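Swapping an octyl chain for a fluoro-nitrophenyl ring

The source may report more compounds than this note shows. Statements on the series, on what has been measured and on what is new or still open speak of the compounds shown alone.

Measured compounds:
Compound 1, `CCOC(=O)C1=Cc2ccccc2OC1(OCc1cn(CC(=O)NC2CCCCC2)nn1)C(F)(F)F`, 9900 nM
Compound 2, `CCOC(=O)C1=Cc2ccccc2OC1(OCc1cn(CC(=O)Nc2ccc(C)cc2)nn1)C(F)(F)F`, 54300 nM
Compound 3, `CCCCCCCCn1cc(COC2(C(F)(F)F)Oc3ccccc3C=C2C(=O)OCC)nn1`, > 150000 nM

All three share one core and differ only in the group carried on the nitrogen of the five-membered ring with three nitrogens. In a functional assay on A549 cells (Homo sapiens) for inhibition, read by MTT assay, with a stated time of 24 h (on this read-out higher numbers stand for weaker inhibition and lower numbers for stronger inhibition), compound 1 gives 9900 nM. Compound 2 gives 54300 nM, and the step of a 5.5-fold higher number from compound 1 to compound 2 (0.74 log units; beyond the scatter). For compound 3 the number is only a limit of the assay, (the limit of > 150000 nM in this assay, at which 1 of the 3 values shown sits), so compound 3 stands at the weak end of what has been measured. The steps of an at least 15-fold higher number from compound 1 to compound 3 (1.18 log units; beyond the scatter) and an at least 2.7-fold higher number from compound 2 to compound 3 (0.44 log units; beyond the scatter) show that a plain chain on this nitrogen loses inhibition compared with the two carbamoyl-bearing chains.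

Compound 4 is `CCOC(=O)C1=Cc2ccccc2OC1(OCc1cn(-c2ccc(F)c([N+](=O)[O-])c2)nn1)C(F)(F)F`. Its difference from compound 3 is 4-fluoro-3-nitrophenyl in place of octyl on an aromatic nitrogen. The two measured steps that reach compound 3 both ran in the direction of weaker inhibition when the ring-bearing or amide-bearing group was removed; compound 4 restores a ring, though without the amide. A moderate move back toward stronger inhibition is therefore expected, with the estimate uncertain because compound 3 shows only > 150000 nM. The expected step is an at least 2.5-fold lower number from compound 3 to compound 4 (0.39 log units; beyond the scatter). For compound 4 the estimate in this assay is 60000 nM, between 20000 nM and 200000 nM.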

Compound 4, half-maximal inhibitory concentration: 11900 nM
For compound 4 the middle estimate is 5.0-fold (0.70 log units) above the measured one; measured number outside the range, below it.
By their numbers in this assay, from the lowest: compounds 1 and 4 (each within the scatter of the next); then compound 2. At a limit, above all of these: compound 3.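

An amide is not needed on this nitrogen for a low number in this assay: compound 4 carries 4-fluoro-3-nitrophenyl directly on the five-membered ring with three nitrogens, with no amide, and the step is a 1.2-fold higher number from compound 1 to compound 4 (0.08 log units; within the scatter), so compound 1 and compound 4 cannot be told apart here. An amide-bearing chain does not by itself give the lower number either, since the comparison with the amide-bearing compound 2 gives a 4.6-fold lower number from compound 2 to compound 4 (0.66 log units; beyond the scatter). Replacing the octyl chain gives an at least 12-fold lower number from compound 3 to compound 4 (1.10 log units; beyond the scatter), a large change whose full size stays unknown, since compound 3 rests on a limit of the assay: the limit of > 150000 nM in this assay, at which 1 of the 4 values shown sits.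

The compounds shown leave open whether the low number of compound 4 belongs to the aromatic ring itself or to its fluorine and nitro groups, a question that a plain phenyl ring on this nitrogen, or an amino group in place of the nitro group, would help to answer. They also leave open whether a cyclohexyl ring set directly on this nitrogen, without the amide-bearing chain, would match compound 1 and compound 4.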